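Fluorophenyl amide variation on the quinoline series

This account rests on a few compounds, and the source may have more. Where it says the series, first, only, none or still open, it means among the compounds named here.

The series shares one core carrying a methyl group, a cyclic amine and an anilide; compound 1 `CCN1CCN(c2cc(C)c3cc(NC(=O)c4ccccc4F)ccc3n2)CC1` carries a 2-fluorophenyl on the carbonyl carbon and an ethylpiperazine. In a functional assay on MCF7 cells (Homo sapiens) for antiproliferative activity, read by MTT assay, with a stated time of 72 h (on this read-out lower numbers stand for stronger inhibition and higher numbers for weaker inhibition), compound 1 gives 32600 nM, the highest of the three numbers. Compound 2 `Cc1cc(N2CCCCC2)nc2ccc(NC(=O)c3ccc(Cl)c(Cl)c3)cc12` gives 31100 nM, which sits within the scatter of compound 1. Among the measured compounds shown here, compound 3 `Cc1cc(N2CCN(C(C)C)CC2)nc2ccc(NC(=O)c3ccc(Cl)c(Cl)c3)cc12` gives 1710 nM; the only single-place step in the set, an 18-fold lower number from compound 2 to compound 3 (1.26 log units; beyond the scatter), concerns the cyclic amine, not the amide.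

Compound 4 `CCN1CCN(c2cc(C)c3cc(NC(=O)c4cccc(F)c4)ccc3n2)CC1` differs from compound 1 in the amide alone: 3-fluorophenyl in place of 2-fluorophenyl on a carbonyl carbon. For the measured compounds named here, no measured step touches this part of the molecule, so the large amine step offers no guidance here, and the two amide variants measured so far (compound 1 and compound 2) differ in more than one place and cannot be read as a step. With nothing in the data pointing in either direction, the expectation for compound 4 is a step of about a 1.1-fold lower number from compound 1 to compound 4 (0.04 log units; within the scatter), that is none beyond the scatter. Compound 4 is therefore estimated at 30000 nM in this assay, within a range of 9000 nM to 100000 nM.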

Compound 4, half-maximal inhibitory concentration: 8920 nM
Compound 4: middle estimate off by 3.4-fold (0.53 log units), on the high side; measured number outside the range, below it.
By their numbers in this assay, from the lowest: compound 3; then compound 4; then compounds 2 and 1 (each within the scatter of the next).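

Among the compounds shown here, the step of a 3.7-fold lower number from compound 1 to compound 4 (0.56 log units; beyond the scatter) in this assay is the first single-place reading at the amide, and it shows that this part of the molecule affects the antiproliferative read-out while the ethylpiperazine and the rest of the core stay fixed. The leaving 2-fluorophenyl and the entering 3-fluorophenyl hold the same atoms and the same aromatic ring, with no hydrogen-bond donors or acceptors on either, so the step comes from a rearrangement of the same atoms rather than from adding or removing any. Nothing available explains why these two fluorophenyl amides part in this way.

The compounds shown leave open whether a phenyl without fluorine, a chlorophenyl or a methoxyphenyl on the same carbonyl carbon would give a lower or a higher number than the 3-fluorophenyl. They also leave open whether this amide step would keep its direction and size with a piperidin-1-yl or a 4-isopropylpiperazin-1-yl group in place of the ethylpiperazine, and whether the amine step an 18-fold lower number from compound 2 to compound 3 (1.26 log units; beyond the scatter) carries over to the fluorophenyl amides.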